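From 4-hydroxyphenyl to 2,6-dimethoxyphenyl on the shared core

A few compounds are considered here, and "the series" means these few. Any claim that something is new, unique, unknown or untested is made for them only; others in the source may bear on it.

Compound 1 `O=C(Cc1csc2nc(-c3ccc(Br)cc3)cn12)N/N=C/c1ccccc1`: 20400 nM
Compound 2 `O=C(Cc1csc2nc(-c3ccc(Br)cc3)cn12)N/N=C/c1ccccc1O`: 12300 nM
Compound 3 `O=C(Cc1csc2nc(-c3ccc(Br)cc3)cn12)N/N=C/c1ccc(O)cc1`: 25700 nM

All three compounds were measured in a functional assay on OVCAR-8 cells (Homo sapiens) for inhibition, read by sulforhodamine B assay, with a stated time of 48 h; a higher number here means a weaker inhibitor of growth, a lower number a stronger inhibitor of growth. Where compound 3 stands is shown by two steps: a 1.3-fold higher number from compound 1 to compound 3 (0.10 log units; within the scatter) and a 2.1-fold higher number from compound 2 to compound 3 (0.32 log units; beyond the scatter), the only one of the pair beyond the scatter. Compound 4 `COc1cccc(OC)c1/C=N/NC(=O)Cc1csc2nc(-c3ccc(Br)cc3)cn12` has 2,6-dimethoxyphenyl in place of 4-hydroxyphenyl on a carbon with a double bond to nitrogen. Within the data shown here, no measured compound carries this group, so the nearest guide is the size of the hydroxy steps, such as a 1.7-fold lower number from compound 1 to compound 2 (0.22 log units; within the scatter). Steps this small give no ground for a large shift in this assay, and none beyond the scatter is expected. The estimated change is a 1.4-fold lower number from compound 3 to compound 4 (0.15 log units; within the scatter). Compound 4 is expected at 18000 nM, within an estimated range from 8000 nM to 40000 nM.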

Compound 4, concentration for total growth inhibition: 38000 nM
For compound 4 the middle estimate is 2.1-fold (0.32 log units) below the measured one, within the range that was stated.
By their numbers in this assay, from the lowest: compounds 2, 1, 3 and 4 (each within the scatter of the next, the first and the last beyond it).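

At this position, on a carbon with a double bond to nitrogen, 2,6-dimethoxyphenyl stays within the scatter of phenyl and 4-hydroxyphenyl in this assay, with a 1.9-fold higher number from compound 1 to compound 4 (0.27 log units; within the scatter) and a 1.5-fold higher number from compound 3 to compound 4 (0.17 log units; within the scatter) as its steps. Among these compounds, only 2-hydroxyphenyl stands apart from it, with a 3.1-fold higher number from compound 2 to compound 4 (0.49 log units; beyond the scatter) as the one step beyond the scatter. The data offer nothing that explains this separation.

On these data alone, whether a single methoxy group behaves as the pair does remains open. So does whether an amine or a carboxylic acid on this ring would shift the number further.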